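The compounds below may be only part of what the source reports. "The series", "measured", "known", "first", "only" and "open" are said of these compounds alone.

Compound 1 `COc1cc(CC(O)c2ccc(-c3ccc(C=O)cc3)cc2)c([N+](=O)[O-])cc1OC` was tested in an ADME assay on HeLa Rh cells (Homo sapiens) for cytotoxicity, read by microscopy; a higher number here means that more compound is tolerated, a lower number that less compound is tolerated. For compound 1 the result is a limit and not a number, > 245000 nM, which is where (the limit of > 245000 nM in this assay, at which 1 of the 3 values shown sits). Compound 2 `COc1cc(CC(O)c2ccc(-c3ccc(C(F)(F)F)cc3)cc2)c([N+](=O)[O-])cc1OC` gives 4100 nM in this assay, and compound 3 `COc1cc(CC(O)c2ccc(-c3ccc(F)cc3)cc2)c([N+](=O)[O-])cc1OC` gives 4500 nM. Both steps away from compound 1 are large: an at least 59-fold lower number from compound 1 to compound 2 (1.77 log units; beyond the scatter), and an at least 54-fold lower number from compound 1 to compound 3 (1.73 log units; beyond the scatter). Between the two replacements there is no difference worth noting, since a 1.1-fold higher number from compound 2 to compound 3 (0.04 log units; within the scatter). On the numbers shown, compound 1 stands apart at the limit, while compound 2 and compound 3 sit close together.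

Compound 4 `COc1cc(CC(O)c2ccc(-c3ccccc3C#N)cc2)c([N+](=O)[O-])cc1OC` has not yet been measured in this assay. It differs from compound 1 in one place: 2-cyanophenyl in place of 4-formylphenyl on an aromatic carbon. The measured steps that bear on it are the two that start from compound 1, in each of which the formyl group was exchanged and the number fell by a large margin. The group that enters here is a 2-cyanophenyl rather than a fluoro or trifluoromethyl variant, so the step is not a repetition of those measured, but the only trend available is that exchanging the formyl lowers the number sharply. Compound 4 is therefore expected to give about 6000 nM, with a range from 1500 nM to 60000 nM. The step this estimate implies is an at least 40-fold lower number from compound 1 to compound 4 (1.61 log units; beyond the scatter).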

Compound 4, half-maximal cytotoxic concentration: 9300 nM
For compound 4 the middle estimate is 1.6-fold (0.19 log units) below the measured one, and the stated range covers the measured number.
By their numbers in this assay, from the lowest: compounds 2 and 3 (each within the scatter of the next); then compound 4. At a limit, above all of these: compound 1.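

Compound 4 adds a third replacement of the 4-formylphenyl group, and it too lies far lower, with an at least 26-fold lower number from compound 1 to compound 4 (1.42 log units; beyond the scatter); among the compounds shown, none goes against this, and the drop now also holds for a group carrying a nitrile instead of a halogen-bearing group. It also gives the first separation beyond the scatter among the replacements, though a modest one, with a 2.1-fold higher number from compound 3 to compound 4 (0.32 log units; beyond the scatter) and a 2.3-fold higher number from compound 2 to compound 4 (0.36 log units; beyond the scatter). The true size of the drop from compound 1 stays unknown, since the value for compound 1 is a limit and not a number: the limit of > 245000 nM in this assay, at which 1 of the 4 values shown sits.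

The 2-cyanophenyl group differs from the 4-fluorophenyl and 4-(trifluoromethyl)phenyl groups both in what it carries and in where it carries it, so these compounds cannot show which of the two accounts for the modest rise. Also open, as far as these compounds go, is whether the high tolerance in this assay belongs to the formyl group alone, or would also appear with a carboxylic acid, an amine or a hydroxymethyl group in its place.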